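Working notes: the ring change from compound 3 to compound 4

This account rests on a few compounds, and the source may have more. Where it says the series, first, only, none or still open, it means among the compounds named here.

- compound 1 `Cc1cc(Nc2ncnc3cc(O)c(NC(=O)/C=C/[C@H]4CCCN4C)cc23)ccc1Oc1cnc2ccnn2c1`: 3.11 nM
- compound 2 `C=C(F)C(=O)Nc1cc2c(Nc3ccc(Oc4cc5nncn5cn4)c(C)c3)ncnc2cc1OCC`: 3.88 nM
- compound 3 `Cc1cc(Nc2ncnc3cc(O)c(NC(=O)/C=C/[C@H]4CCCN4C)cc23)ccc1Oc1ccn2ccnc2c1`: 4.63 nM

All three values come from a functional assay on BT-474 cells (Homo sapiens) for inhibition, read by CellTiter-Glo, with a stated time of 72 h; on this read-out higher numbers stand for weaker inhibition and lower numbers for stronger inhibition. Compound 3, at 4.63 nM, lies within the scatter of both compound 1 and compound 2, so the three values give no order. Compound 4 `Cc1cc(Nc2ncnc3cc(O)c(NC(=O)/C=C/[C@H]4CCCN4C)cc23)ccc1Oc1ccn2cnnc2c1` is not yet measured. Its change is a group of 9 heavy atoms (6 carbon, 3 nitrogen; one five-membered aromatic ring with 3 hetero atoms, one six-membered aromatic ring with 1 hetero atom) in place of a group of 9 heavy atoms (7 carbon, 2 nitrogen; one five-membered aromatic ring with 2 hetero atoms, one six-membered aromatic ring with 1 hetero atom), on an oxygen on an aromatic ring. Going by the values given here, one measured step bears on this place: a 1.5-fold higher number from compound 1 to compound 3 (0.17 log units; within the scatter), a similar ring change that stayed within the scatter. Among the compounds with values here, compound 2 offers no single-place step. The expected step in this assay is therefore a 1.0-fold lower number from compound 3 to compound 4 (0.01 log units; within the scatter), with nothing expected beyond the scatter and neither direction favoured. For compound 4 the estimate is 4.5 nM, with an expected range of 2 nM to 10 nM.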

Compound 4, half-maximal inhibitory concentration: 26.8 nM
Estimate against measurement, compound 4: 6.0-fold (0.77 log units) below; the measured number lies above the stated range.
By their numbers in this assay, from the lowest: compounds 1, 2 and 3 (each within the scatter of the next); then compound 4.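

In this assay, the group on this oxygen proves to matter: a 5.8-fold higher number from compound 3 to compound 4 (0.76 log units; beyond the scatter) and an 8.6-fold higher number from compound 1 to compound 4 (0.94 log units; beyond the scatter) both lie beyond the scatter, whereas the earlier ring change stayed within it. The higher number of compound 4 is read within this core only, as compound 2 differs in more than one place and cannot be set against it. No measurement shown here accounts for the step. Still open, as far as these compounds go, is how a simple phenyl or a pyridine on that oxygen would read out on this core.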